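Methoxy on the phenyl group of compound 2

This account rests on a few compounds, and the source may have more. Where it says the series, first, only, none or still open, it means among the compounds named here.

Values in a functional assay on HeLa cells (Homo sapiens) for antiproliferative activity, read by MTT assay, with a stated time of 48 h; a higher number here means a weaker inhibitor, a lower number a stronger inhibitor
compound 1 `C#Cc1cccc(Nc2ncnc3cc(NC(=O)/C=C/c4ccccc4)sc23)c1` gives 20500 nM
compound 2 `O=C(/C=C/c1ccccc1)Nc1cc2ncnc(Nc3ccc(F)c(Cl)c3)c2s1` gives 2810 nM
compound 3 `O=C(/C=C/c1ccccc1)Nc1cc2ncnc(Nc3cc(Cl)cc(Cl)c3)c2s1` gives 3210 nM

Compound 2 shares the low end of these numbers with compound 3 and the gap is a 1.1-fold higher number from compound 2 to compound 3 (0.06 log units; within the scatter) here. Compound 4 `COc1ccc(/C=C/C(=O)Nc2cc3ncnc(Nc4ccc(F)c(Cl)c4)c3s2)cc1` differs from compound 2 by methoxy in place of hydrogen on an aromatic carbon in the 2-phenylethenyl group. Among the compounds with values here, no measured step touches this group. The nearest guides are changes of the aryl group on nitrogen, namely the modest 7.3-fold lower number from compound 1 to compound 2 (0.86 log units; beyond the scatter) and the modest 6.4-fold lower number from compound 1 to compound 3 (0.81 log units; beyond the scatter) in this assay as well as the gap above. A small step of unsettled direction is therefore expected, and a 1.1-fold higher number from compound 2 to compound 4 (0.06 log units; within the scatter) is the estimated step. For compound 4 the estimate is 3200 nM with 1300 nM to 8000 nM as the expected range.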

Compound 4, half-maximal inhibitory concentration: 20600 nM
Compound 4: the middle estimate sits 6.4-fold (0.81 log units) below what was measured; the measured number lies above the stated range.
By their numbers in this assay, from the lowest: compounds 2 and 3 (each within the scatter of the next); then compounds 1 and 4 (each within the scatter of the next).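

The 2-phenylethenyl end of the series is not neutral: in this assay, methoxy in place of hydrogen, para to a large group, gives a 7.3-fold higher number from compound 2 to compound 4 (0.87 log units; beyond the scatter) with the aryl group on nitrogen unchanged. This end of the molecule can therefore shift the number on its own, and here the added methoxy moves it upward. No measured finding accounts for this step.

On these data alone, whether the rise is specific to methoxy or follows from any group at this place remains open. An amine, a fluorine or a carboxylic acid on this ring would help separate these readings.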